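Changing the ring on the carbon double-bonded to nitrogen

The compounds below may be only part of what the source reports. "The series", "measured", "known", "first", "only" and "open" are said of these compounds alone.

Compound 1 `CN(C)CCn1cnnc1-c1cc(Oc2ccc(NC(=O)N/N=C/c3ccc(Cl)cc3)cc2F)ccn1` is the reference point of the series. In a functional assay on A549 cells (Homo sapiens) for cytotoxicity, read by MTT assay, with a stated time of 72 h (a lower number here means a stronger inhibitor, a higher number a weaker inhibitor), compound 1 gives 780 nM. Compound 2 `CN(C)CCn1cnnc1-c1cc(Oc2ccc(NC(=O)N/N=C/c3cccc(Cl)c3Cl)cc2F)ccn1` gives 1090 nM in the same this assay, and compound 3 `CN(C)CCn1cnnc1-c1cc(Oc2ccc(NC(=O)N/N=C/c3ccccc3O[N+](=O)[O-])cc2F)ccn1` gives 1200 nM. Compound 1 thus carries the lowest number of the three, but the steps of a 1.4-fold higher number from compound 1 to compound 2 (0.15 log units; within the scatter) and a 1.5-fold higher number from compound 1 to compound 3 (0.19 log units; within the scatter) both lie within the scatter, and so does a 1.1-fold higher number from compound 2 to compound 3 (0.04 log units; within the scatter), so no order among the three can be read from these numbers.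

Compound 4 `Cc1cc(/C=N/NC(=O)Nc2ccc(Oc3ccnc(-c4nncn4CCN(C)C)c3)c(F)c2)cc(C)c1O` is not yet measured. It differs from compound 1 in one place: 4-hydroxy-3,5-dimethylphenyl in place of 4-chlorophenyl on a carbon with a double bond to nitrogen. The measured steps that bear on this change are the three exchanges of the ring on a carbon with a double bond to nitrogen, a 1.4-fold higher number from compound 1 to compound 2 (0.15 log units; within the scatter), a 1.5-fold higher number from compound 1 to compound 3 (0.19 log units; within the scatter) and a 1.1-fold higher number from compound 2 to compound 3 (0.04 log units; within the scatter), none of which moved the number beyond the scatter. No step beyond the scatter is therefore expected in this assay for compound 4 either, with the range widened to allow for the new hydroxyl and the new ring not having been tried before. The expected value for compound 4 in this assay is 950 nM, estimated to lie between 350 nM and 2600 nM. This estimate corresponds to an expected step of a 1.2-fold higher number from compound 1 to compound 4 (0.09 log units; within the scatter).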

Compound 4, half-maximal inhibitory concentration: 1640 nM
Compound 4: middle estimate off by 1.7-fold (0.24 log units), on the low side, within the range that was stated.
By their numbers in this assay, from the lowest: compounds 1, 2, 3 and 4 (each within the scatter of the next, the first and the last beyond it).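

Within the data shown here, the ring on the carbon with a double bond to nitrogen now gives the only step beyond the scatter at this position in this assay, a modest one, with 4-hydroxy-3,5-dimethylphenyl in place of 4-chlorophenyl (a 2.1-fold higher number from compound 1 to compound 4 (0.32 log units; beyond the scatter)). The separation holds against compound 1 alone, since the other two exchanges stay within the scatter (a 1.4-fold higher number from compound 3 to compound 4 (0.14 log units; within the scatter); a 1.5-fold higher number from compound 2 to compound 4 (0.18 log units; within the scatter)). Nothing available explains this step, and these compounds cannot show whether the hydroxyl or the methyl groups carry it.

Still open, going by these compounds, is how the 4-chlorophenyl reference compares with a ring carrying only the hydroxyl or only the methyl groups. Also open, on these data alone, is how an amine or a carboxylic acid in place of the hydroxyl would read at this position.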